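Adding a Second Chloro to the Purine Core

This account rests on a few compounds, and the source may have more. Where it says the series, first, only, none or still open, it means among the compounds named here.

Measured compounds:
Compound 1 `ClCc1ccc(Cn2cnc3c(Cl)ncnc32)cc1`: > 100000 nM
Compound 2 `ClCc1ccccc1Cn1cnc2c(Cl)nc(Cl)nc21`: 5920 nM
Compound 3 `ClCc1cccc(Cn2cnc3c(Cl)ncnc32)c1`: 89100 nM

These three compounds were tested in a functional assay on UO-31 cells (Homo sapiens) for cytotoxicity, read by sulforhodamine B assay, with a stated time of 48 h; on this read-out lower numbers stand for higher toxicity in this test and higher numbers for lower toxicity in this test. Compound 1 gives only a limit of the assay, not a number, and this limit is the limit of > 100000 nM in this assay, at which 1 of the 3 values shown sits. Among the two numbers that remain, compound 3 stands highest; compound 2 gives a lower number, and the gap between them lies beyond the usual scatter. Compound 2 differs from compound 3 in more than one place, so its value shows only where it lands and nothing about a single change.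

Compound 4 `ClCc1cccc(Cn2cnc3c(Cl)nc(Cl)nc32)c1` has not yet been measured. It differs from compound 3 by chloro in place of hydrogen on an aromatic carbon. Within the data shown here, no measured pair in this set isolates that change, so the expected size of the step rests on the spread of the numbers seen so far. Compound 4 is expected to give a lower number than compound 3, with a step of a 3.0-fold lower number from compound 3 to compound 4 (0.47 log units; beyond the scatter) estimated as modest but beyond the scatter. The estimate for compound 4 is 30000 nM, with a range from 8000 nM to 100000 nM.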

Compound 4, concentration lethal to 50% of the cells: 5880 nM
The estimate for compound 4 lay 5.1-fold (0.71 log units) above the measured number; the whole stated range lies above it.
By their numbers in this assay, from the lowest: compounds 4 and 2 (each within the scatter of the next); then compound 3. At a limit, above all of these: compound 1.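

In this assay, among these compounds, chloro in place of hydrogen on the aromatic carbon between two ring nitrogen atoms gives a 15-fold lower number from compound 3 to compound 4 (1.18 log units; beyond the scatter) and is the first change in this set that can be read on its own. A lower number here stands for higher toxicity in this test, so this one position on the shared core clearly matters for the read-out, and a single added chlorine is enough to show it. Compound 4 gives 5880 nM and compound 2 gives 5920 nM, two values within the usual scatter of each other, yet nothing measured here explains the size of the step.

The compounds shown leave open whether this position responds only to chloro or also to other groups, such as an amine, a methoxy group or a longer chain. They also leave open whether the same chloro would change the result for compound 1, whose value is only a limit of the assay and not a number.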